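Pyrrolidin-1-yl for dimethylamino: expected step for compound 4

A few compounds are considered here, and "the series" means these few. Any claim that something is new, unique, unknown or untested is made for them only; others in the source may bear on it.

Measured so far in an ADME assay on L6 cells (Rattus norvegicus) for cytotoxicity; a higher number here means a weaker inhibitor, a lower number a stronger inhibitor
- compound 1 `CN1CCN(CCCN2CCC3(N(C)C)CC(c4ccccc4)C2C(c2ccccc2)C3)CC1` gives 54500 nM
- compound 2 `CN1CCN(CCCN2CCC3(N4CCN(C)CC4)CC(c4ccccc4)C2C(c2ccccc2)C3)CC1` gives 47800 nM
- compound 3 `CN1CCN(CCN2CCC3(N(C)C)CC(c4ccccc4)C2C(c2ccccc2)C3)CC1` gives 70300 nM

Compound 3 lies within the scatter of both compound 1 and compound 2, so the three values show one level. Compound 4 `CN1CCN(CCN2CCC3(N4CCCC4)CC(c4ccccc4)C2C(c2ccccc2)C3)CC1` carries pyrrolidin-1-yl in place of dimethylamino on a saturated ring carbon. For the measured compounds named here, the one measured swap at that carbon gave (a 1.1-fold lower number from compound 1 to compound 2 (0.06 log units; within the scatter)) and the chain change gave (a 1.3-fold higher number from compound 1 to compound 3 (0.11 log units; within the scatter)), both within the scatter. No step beyond the scatter is therefore expected in this assay for this swap. The expected step is small (a 1.1-fold lower number from compound 3 to compound 4 (0.05 log units; within the scatter)) and stays within the scatter. Compound 4 is estimated at 62000 nM with an expected range from 33000 nM to 110000 nM in this read-out.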

Compound 4, half-maximal inhibitory concentration: 50300 nM
Compound 4: the middle estimate sits 1.2-fold (0.09 log units) above what was measured; measured number inside the range.
By their numbers in this assay, from the lowest: compounds 2, 4, 1 and 3 (each within the scatter of the next).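

In this assay, the first five-membered ring at this saturated ring carbon gives a 1.4-fold lower number from compound 3 to compound 4 (0.15 log units; within the scatter), so the swap of dimethylamino for pyrrolidin-1-yl leaves the number at the same level. With 4-methylpiperazin-1-yl in a 1.1-fold lower number from compound 1 to compound 2 (0.06 log units; within the scatter), two ring amines at this carbon have now been read against dimethylamino, and neither step lies beyond the scatter. No measured evidence bears on this result.

All four compounds carry a tertiary amine at this carbon. Going by these compounds, whether a primary amine or a carboxylic acid there would give a step beyond the scatter remains open.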